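The source may hold more compounds than are shown below. What is called first, only, known or untested is meant among the compounds shown, and "the series" means these compounds.

Compound 1 `O=S(=O)(Nc1ccccc1Cl)c1ccc(-c2cnc(C3CC3)o2)cc1` gives 49700 nM
Compound 2 `Cc1cc(Cl)ccc1NS(=O)(=O)c1ccc(-c2cnc(C3CC3)o2)cc1` gives 54700 nM

For the measured compounds named here, in a functional assay on cells (leukaemia cell line, Homo sapiens) for inhibition, read by sulforhodamine B assay, with a stated time of 48 h (a higher number here means a weaker inhibitor of growth, a lower number a stronger inhibitor of growth), compound 2 stands level with compound 1 on the two numbers so far. Compound 3 `Cc1cc(F)cc(NS(=O)(=O)c2ccc(-c3cnc(C4CC4)o3)cc2)c1` is the next analogue, with this change from compound 2: 3-fluoro-5-methylphenyl in place of 4-chloro-2-methylphenyl on a sulfonamide nitrogen. The group on the sulfonamide nitrogen is the only part that differs. Going by the values given here, one measured step bears on this change, since it alters the same group: a 1.1-fold higher number from compound 1 to compound 2 (0.04 log units; within the scatter). That is a single small step, so no shift beyond the scatter is expected in this assay and no direction is favoured. The expected step is a 1.1-fold lower number from compound 2 to compound 3 (0.06 log units; within the scatter). For compound 3 the estimate is 48000 nM, with an estimated range of 22000 nM to 95000 nM.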

Compound 3, concentration for total growth inhibition: 7250 nM
The estimate for compound 3 lay 6.6-fold (0.82 log units) above the measured number; measured number outside the range, below it.
By their numbers in this assay, from the lowest: compound 3; then compounds 1 and 2 (each within the scatter of the next).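

In this assay the group on the sulfonamide nitrogen can move the number beyond the scatter: 3-fluoro-5-methylphenyl gives a 7.5-fold lower number from compound 2 to compound 3 (0.88 log units; beyond the scatter) and a 6.9-fold lower number from compound 1 to compound 3 (0.84 log units; beyond the scatter), so this position is not flat across aryl groups. The change swaps chlorine for fluorine and alters the substitution pattern at once, and the compounds shown cannot separate the two. Nothing measured here accounts for the shift.

Still open, from the compounds shown here alone, is whether 3-chloro-5-methylphenyl would hold the lower number. Also open, going by these compounds, is how a phenyl ring carrying an amine or a carboxylic acid would read.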